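Fluoro substitution on the amide aryl ring across two cores

The source may hold more compounds than are shown below. What is called first, only, known or untested is meant among the compounds shown, and "the series" means these compounds.

Compound 1 `COc1ccc(-n2ccc(=O)c(C(=O)Nc3ccc(Oc4ccnc5c4ccn5C)cc3)n2)cc1` and compound 2 `COc1ccc(-n2ccc(=O)c(C(=O)Nc3ccc(Oc4ccnc5c4ccn5C)c(F)c3)n2)cc1` share one core; compound 3 `Cc1cc(=O)n(-c2ccccc2OC(F)(F)F)nc1C(=O)Nc1ccc(Oc2ncnc3c2ccn3C)cc1` is built on another, and compound 4 `Cc1cc(=O)n(-c2ccccc2OC(F)(F)F)nc1C(=O)Nc1ccc(Oc2ncnc3c2ccn3C)c(F)c1` is not yet measured. The difference between the two cores is not broken down here. In a functional assay on PC-3 cells (Homo sapiens) for cytotoxicity, read by MTT assay, with a stated time of 72 h (a lower number here means a stronger inhibitor, a higher number a weaker inhibitor), compound 1 gives > 60000 nM, which is a limit of the assay and not a number. Compound 2 gives > 60000 nM in this assay, again a limit. Among the compounds with values here, compound 3 gives 5160 nM in this assay, the only number among the three values shown, while the limit of > 60000 nM in this assay, at which 2 of the 3 values shown sit, covers the other two. The change from compound 1 to compound 2 is fluoro in place of hydrogen on an aromatic carbon, and the step that the two limits leave unreadable from compound 1 to compound 2. The same change is made from compound 3 to compound 4: fluoro in place of hydrogen on an aromatic carbon. With the measured step unreadable, no size can be carried over from it. The step of a 1.1-fold lower number from compound 3 to compound 4 (0.06 log units; within the scatter) is expected to be small. This rests on compound 3, whose value 5160 nM in this assay serves as the anchor. Compound 4 is therefore estimated at 4500 nM in this assay, with a likely range from 1500 nM to 15000 nM.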

Compound 4, half-maximal inhibitory concentration: > 60000 nM
Compound 4 was reported as a limit; the forecaster's own chance of this, stated with the estimate: 5%; middle value at least 13-fold (1.12 log units) away from the limit.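

In this assay, fluoro in place of hydrogen on an aromatic carbon gives an at least 11-fold higher number from compound 3 to compound 4 (1.06 log units; beyond the scatter), so on the core of compound 3 the change goes with a clear loss of activity, the opposite of a neutral swap. Compound 4 gives > 60000 nM, which is a limit of the assay and not a number. The step on the core of compound 1 cannot be read, so there is no measured size to set against the new step, nothing shows whether the change carries from one core to the other, and only compound 3 holds a number: the limit of > 60000 nM in this assay, at which 3 of the 4 values shown sit.

As far as these compounds go, whether another group on the same aromatic carbon, such as chloro, a nitrile or an amine, would keep the activity of compound 3 remains open. A number in place of a limit on the core of compound 1 would also be needed before the two cores could be compared for this change.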